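The source may hold more compounds than are shown below. What is called first, only, known or untested is meant among the compounds shown, and "the series" means these compounds.

Measured so far in an assay on isolated protein for inhibition of protein deacetylase HDAC6 (Homo sapiens), read by fluorescence, with a stated time of 15 min; a lower number here means a stronger inhibitor, a higher number a weaker inhibitor:
- compound 1 `Nc1ccccc1NC(=O)c1ccc(-c2nnc(Cc3cccc4ccccc34)o2)cc1` gives 16100 nM.
- compound 2 `Nc1ccccc1NC(=O)c1ccc(Cc2nnc(Cc3cccc4ccccc34)o2)cc1` gives 8900 nM.
- compound 3 `Nc1ccccc1NC(=O)/C=C/c1ccc(Cc2nnc(Cc3cccc4ccccc34)o2)cc1` reaches only a limit of the assay, > 20000 nM.

Compound 1 sits with compound 2 inside the usual scatter of this assay, so neither number can be ranked against the other. Compound 3 stands at the limit of > 20000 nM in this assay, at which 1 of the 3 values shown sits, nothing more. Compound 4 `O=C(/C=C/c1ccc(-c2nnc(Cc3cccc4ccccc34)o2)cc1)NO` differs from compound 1 in one place: 2-(hydroxycarbamoyl)ethenyl in place of (2-aminophenyl)carbamoyl on an aromatic carbon. Within the data shown here, no measured pair tracks this change, so the step rests on expectation alone. A large move toward a lower number in this assay is expected, a 270-fold lower number from compound 1 to compound 4 (2.43 log units; beyond the scatter). Compound 4 is estimated at 60 nM, with a range from 10 nM to 600 nM.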

Compound 4, half-maximal inhibitory concentration: 60 nM
Compound 4: middle estimate and measured number agree at the digits printed, within the range that was stated.
By their numbers in this assay, from the lowest: compound 4; then compounds 2 and 1 (each within the scatter of the next). At a limit, above all of these: compound 3.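

With 2-(hydroxycarbamoyl)ethenyl in place of (2-aminophenyl)carbamoyl on an aromatic carbon para to a large group, this assay shows a 270-fold lower number from compound 1 to compound 4 (2.43 log units; beyond the scatter). Among these compounds, this is the first step, and it shows that the number responds strongly to the group at this place while the rest of the core of compound 1 stays the same. Nothing measured here bears on the cause of this step.

As far as these compounds go, whether the hydroxycarbamoyl end or the ethenyl chain carries the step stays open. A carboxylic acid on the ethenyl chain, or hydroxycarbamoyl without that chain, would separate the two.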